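Pyrrolidine for Piperidine on a Bridged Cytotoxicity Series

A few compounds are considered here, and "the series" means these few. Any claim that something is new, unique, unknown or untested is made for them only; others in the source may bear on it.

Three related compounds were examined in an ADME assay on L6 cells (Rattus norvegicus) for cytotoxicity; a lower number here means a stronger inhibitor, a higher number a weaker inhibitor. Compound 1 `CN(C)C12CCN(CCN3CCCC3)C(C(c3ccccc3)C1)C(c1ccccc1)C2` gives 80400 nM. Compound 2 `CN1CCN(CC(=O)N2CCC3(N4CCCC4)CC(c4ccccc4)C2C(c2ccccc2)C3)CC1` gives 69100 nM. Compound 3 `c1ccc(C2CC3(N4CCCCC4)CC(NCN4CCCC4)C2C(c2ccccc2)C3)cc1` gives 43000 nM, the lowest of the three numbers, yet its gaps to compound 2 and to compound 1 both lie within the usual scatter, so no order among them can be claimed.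

Compound 4 `c1ccc(C2CC3(N4CCCC4)CC(NCN4CCCC4)C2C(c2ccccc2)C3)cc1` differs from compound 3 in one place: pyrrolidin-1-yl in place of piperidin-1-yl on a saturated ring carbon. Among the measured compounds shown here, no measured pair in this set shows such a change, so there is no basis for expecting a shift beyond the scatter in this assay. The step from compound 3 to compound 4 is estimated at a 1.0-fold higher number from compound 3 to compound 4 (0.02 log units; within the scatter). For compound 4 the expected value in this assay is 45000 nM, with a range from 18000 nM to 110000 nM.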

Compound 4, half-maximal inhibitory concentration: 30600 nM
Compound 4: middle estimate off by 1.5-fold (0.17 log units), on the high side; the measured number falls inside the stated range.
By their numbers in this assay, from the lowest: compounds 4, 3, 2 and 1 (each within the scatter of the next, the first and the last beyond it).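

Among the compounds shown here, this is the first direct comparison at this position: in this assay, pyrrolidin-1-yl in place of piperidin-1-yl on a saturated ring carbon gives a 1.4-fold lower number from compound 3 to compound 4 (0.15 log units; within the scatter). On this core, the five-membered and six-membered rings therefore cannot be told apart in this assay. No available evidence bears on this result.

The compounds shown leave open whether a morpholin-4-yl group or a carboxylic acid at this ring carbon would shift the number beyond the scatter. They also leave open whether the same exchange would hold on a core with a different side chain.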